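Chloro in place of hydrogen on the anilide: compound 4

A few compounds are considered here, and "the series" means these few. Any claim that something is new, unique, unknown or untested is made for them only; others in the source may bear on it.

Compound 1, `Cc1noc(C)c1-c1cnc(N)c(Oc2ccc(C(=O)Nc3ccccc3)cc2)n1`, gives 26600 nM in a functional assay on U-87MG ATCC cells for inhibition, with U-87 MG (Homo sapiens) as the target, read by MTT assay, with a stated time of 72 h; a higher number here means a weaker inhibitor, a lower number a stronger inhibitor.
Compound 2, `Cc1noc(C)c1-c1cnc(N)c(Oc2ccc(C(=O)Nc3ccccc3Cl)cc2)n1`, gives 60500 nM in this assay.
Compound 3, `Cn1cc(-c2cnc(N)c(Oc3ccc(C(=O)Nc4ccccc4)cc3)n2)cn1`, gives 17700 nM in this assay.

Compound 3 holds the lowest of the three numbers in this assay. Its nearest neighbour is compound 1, and the step of a 1.5-fold lower number from compound 1 to compound 3 (0.18 log units; within the scatter) lies within the scatter, so the two cannot be ordered. Compound 2 is furthest away; its number sits beyond the scatter from that of compound 3.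

Compound 4, `Cn1cc(-c2cnc(N)c(Oc3ccc(C(=O)Nc4ccccc4Cl)cc3)n2)cn1`, differs from compound 3 by chloro in place of hydrogen on an aromatic carbon. The same change has been measured once, on the core of compound 1: the step of a 2.3-fold higher number from compound 1 to compound 2 (0.36 log units; beyond the scatter) is modest but beyond the scatter, giving a higher number, that is, a weaker inhibitor. Within the data shown here, no other measured pair bears on this change, and the change of the five-membered ring from compound 1 to compound 3 gave a step within the scatter, so there is no sign that the core of compound 3 would answer differently.

Compound 4 is therefore expected to give a higher number than compound 3, by a step of about the size seen with the chloro on the other core, a 2.3-fold higher number from compound 3 to compound 4 (0.35 log units; beyond the scatter). The estimate for compound 4 in this assay is 40000 nM, with a range from 18000 nM to 90000 nM.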

Compound 4, half-maximal inhibitory concentration: 44800 nM
For compound 4 the middle estimate is 1.1-fold (0.05 log units) below the measured one; measured number inside the range.
By their numbers in this assay, from the lowest: compounds 3, 1, 4 and 2 (each within the scatter of the next, the first and the last beyond it).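

In this assay the entry of chloro ortho to a large group no longer rests on a single pair, as the step of a 2.5-fold higher number from compound 3 to compound 4 (0.40 log units; beyond the scatter) is a second modest rise in the number, that is, a weaker inhibitor. The effect of this change therefore reads the same on both cores: the same change on two cores in this assay, a 2.3-fold higher number (0.36 log units; beyond the scatter) from compound 1 to compound 2 and a 2.5-fold higher number (0.40 log units; beyond the scatter) from compound 3 to compound 4, 1.1-fold (0.05 log units) apart, within the scatter of two such steps

The exchange of the five-membered group can now also be read with chloro in place, and the step of a 1.4-fold lower number from compound 2 to compound 4 (0.13 log units; within the scatter) again leaves 1-methyl-1H-pyrazol-4-yl and 3,5-dimethyl-1,2-oxazol-4-yl unordered, so the two changes show no sign of depending on each other within these four compounds: the same change on two cores in this assay, a 1.5-fold lower number (0.18 log units; within the scatter) from compound 1 to compound 3 and a 1.4-fold lower number (0.13 log units; within the scatter) from compound 2 to compound 4, 1.1-fold (0.05 log units) apart, within the scatter of two such steps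

Only hydrogen and chloro are shown at this position, so it stays open whether the loss belongs to chloro alone or to any group placed there, and whether a fluoro, a methoxy or an amine would give a lower number than hydrogen does. Also open is how chloro would read elsewhere on the same six-membered ring, since the compounds shown carry it in one place only.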